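Methyl on the Ring Amide Nitrogen: From Chlorophenyl to Thiophene

A few compounds are considered here, and "the series" means these few. Any claim that something is new, unique, unknown or untested is made for them only; others in the source may bear on it.

Three compounds sharing a fused five-ring core were tested in a functional assay on RPMI18226 cells (Homo sapiens) for antiproliferative activity, read by sulforhodamine B assay, with a stated time of 48 h, tested at 10 uM; on this read-out lower numbers stand for less inhibition and higher numbers for more inhibition at the one concentration tested (going by the name of the read-out). Compound 1 `CN1C[C@@H](c2ccc(Cl)cc2)[C@@]2(Cc3ccccc3C2=O)[C@@]12C(=O)Nc1ccccc12` gives 63.4%. Compound 2 `CN1C(=O)[C@@]2(c3ccccc31)N(C)C[C@@H](c1ccc(Cl)cc1)[C@@]21Cc2ccccc2C1=O` differs by methyl in place of hydrogen on an amide-type nitrogen in a ring and gives 86.6%, so a number 23.2 percentage points higher from compound 1 to compound 2 (beyond the scatter). Compound 3 `CN1C[C@@H](c2cccs2)[C@@]2(Cc3ccccc3C2=O)[C@@]12C(=O)Nc1ccccc12` differs from compound 1 by thiophen-2-yl in place of 4-chlorophenyl on a saturated ring carbon. Compound 3 gives 10.9%, the lowest value of the three; a number 52.5 percentage points lower from compound 1 to compound 3 (beyond the scatter).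

Compound 4 `CN1C(=O)[C@@]2(c3ccccc31)N(C)C[C@@H](c1cccs1)[C@@]21Cc2ccccc2C1=O` is not yet measured. It differs from compound 3 by methyl in place of hydrogen on an amide-type nitrogen in a ring. This is the same change that turns compound 1 into compound 2, at a place described in the same words, and it occurs twice among these compounds. The step from compound 3 to compound 4 is expected to be a number 19.1 percentage points higher from compound 3 to compound 4 (beyond the scatter). Within the data shown here, that expectation rests on a number 23.2 percentage points higher from compound 1 to compound 2 (beyond the scatter), the only earlier instance of this change, although compound 3 starts from a far lower value than compound 1, which adds uncertainty. Compound 4 is therefore estimated at 30%, most likely between 10% and 55%.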

Compound 4, a percentage reported as inhibition, at one concentration (the size of the read-out at that concentration, not a potency): 12.1%
Estimate against measurement, compound 4: 17.9 percentage points above; low and high end bracket the measured number.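

In this assay, the methyl in place of hydrogen on the amide-type nitrogen gives a number 1.2 percentage points higher from compound 3 to compound 4 (within the scatter), so the gain seen with the 4-chlorophenyl group does not carry over to the thiophen-2-yl pair: the same change on two cores in this assay, a number 23.2 percentage points higher (beyond the scatter) from compound 1 to compound 2 and a number 1.2 percentage points higher (within the scatter) from compound 3 to compound 4, 22 percentage points apart, beyond the scatter of two such steps

Read the other way, thiophen-2-yl in place of 4-chlorophenyl gives a number 74.5 percentage points lower from compound 2 to compound 4 (beyond the scatter) when the methyl is present, and this drop also differs in size from the one seen with the amide hydrogen: the same change on two cores in this assay, a number 52.5 percentage points lower (beyond the scatter) from compound 1 to compound 3 and a number 74.5 percentage points lower (beyond the scatter) from compound 2 to compound 4, 22 percentage points apart, beyond the scatter of two such steps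

The two changes therefore do not simply add up in these four compounds, so a step measured on one core is a poor guide to the same step on another, but the data do not show why, and they rest on a single concentration rather than on potency.

From the compounds shown here alone, it remains open how an ethyl group or a longer chain would behave on that nitrogen. Going by these compounds, it is also open whether a plain phenyl or a pyridine ring on the saturated ring carbon would respond to the methyl as the 4-chlorophenyl compounds do or as the thiophen-2-yl compounds do.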